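The source may report more compounds than this note shows. Statements on the series, on what has been measured and on what is new or still open speak of the compounds shown alone.

Three compounds share one core and differ only in the group attached to one aromatic carbon. Compound 1 `OCCCNc1ncnc2[nH]cc(-c3cccc(Cl)c3)c12` carries a (3-hydroxypropyl)amino group, and in an assay for inhibition of serine/threonine-protein kinase 3 (Homo sapiens), read by luminescence and ADP-Glo, in the presence of a further agent that is not named here (a higher number here means a weaker inhibitor, a lower number a stronger inhibitor), compound 1 gives 173 nM. Compound 2 `CC1(O)CCN(c2ncnc3[nH]cc(-c4cccc(Cl)c4)c23)CC1` carries a 4-hydroxy-4-methylpiperidin-1-yl group in that place, and in this assay compound 2 gives 189 nM. Compound 3 `Clc1cccc(-c2c[nH]c3ncnc(N4CCCCC4)c23)c1` carries a plain piperidin-1-yl group, and in this assay compound 3 gives 167 nM. Compound 3 stands at the lowest of the three numbers, yet every gap is small: a 1.0-fold lower number from compound 1 to compound 3 (0.02 log units; within the scatter), a 1.1-fold lower number from compound 2 to compound 3 (0.05 log units; within the scatter), and between the other two a 1.1-fold higher number from compound 1 to compound 2 (0.04 log units; within the scatter). None of these exchanges moved the number beyond the scatter.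

Compound 4 `Clc1cccc(-c2c[nH]c3ncnc(NCC4CC4)c23)c1` takes the next step: (cyclopropylmethyl)amino in place of piperidin-1-yl on an aromatic carbon. The earlier exchanges bear on it, since they already traded an open chain amine for a ring amine on the same carbon without a shift in this assay, as a 1.0-fold lower number from compound 1 to compound 3 (0.02 log units; within the scatter) shows. The expected step is therefore none beyond the scatter, a 1.0-fold higher number from compound 3 to compound 4 (0.02 log units; within the scatter). Compound 4 is estimated at 175 nM in this assay, with a range from 70 nM to 440 nM.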

Compound 4, half-maximal inhibitory concentration: 213 nM
Beside the measured number, compound 4's estimate is 1.2-fold (0.09 log units) below it; low and high end bracket the measured number.
By their numbers in this assay, from the lowest: compounds 3, 1, 2 and 4 (each within the scatter of the next).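

On this aromatic carbon, next to the ring nitrogen, piperidin-1-yl gives way to (cyclopropylmethyl)amino, which brings a hydrogen-bond donor and a three-membered ring of carbon only, and this assay records a 1.3-fold higher number from compound 3 to compound 4 (0.11 log units; within the scatter) for that exchange, so a chain amine ending in a carbon ring is tolerated here as well as the ring amine. The picture is the same against the two groups that carry a hydroxyl, with a 1.1-fold higher number from compound 2 to compound 4 (0.05 log units; within the scatter) when the 4-hydroxy-4-methylpiperidin-1-yl group is replaced and a 1.2-fold higher number from compound 1 to compound 4 (0.09 log units; within the scatter) when cyclopropyl stands in place of 2-hydroxyethyl on the chain, so the four groups shown on this carbon, with or without a hydroxyl and with or without the amine hydrogen, all read alike. No measurement shown offers an explanation for this sameness.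

From the compounds shown here alone, what remains open is whether this flat picture would hold for a group of a different kind on the same carbon, such as a carboxylic acid, a piperazin-1-yl ring or a much longer chain. Going by these compounds, it is also open whether the same exchanges would read alike on a core with something other than the chlorophenyl group.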